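Swapping a ring for a butyl chain on the piperazine-type ring

The source may hold more compounds than are shown below. What is called first, only, known or untested is meant among the compounds shown, and "the series" means these compounds.

Compound 1 `CCN1CCN(C(=S)SCC(O)Cn2c([N+](=O)[O-])cnc2C)CC1`: > 5000000 nM (a limit)
Compound 2 `Cc1ncc([N+](=O)[O-])n1CC(O)CSC(=S)N1CCN(c2ncccn2)CC1`: 2040000 nM

Among the measured compounds shown here, in a toxicity assay on HeLa cells (Homo sapiens) for cytotoxicity, read by MTT assay, with a stated time of 24 h (on this read-out lower numbers stand for stronger inhibition and higher numbers for weaker inhibition), compound 2 holds the only true number so far, 2040000 nM. The entry for compound 1 is a limit of the assay and not a number. Compound 3 `CCCCN1CCN(C(=S)SCC(O)Cn2c([N+](=O)[O-])cnc2C)CC1` carries butyl in place of pyrimidin-2-yl on an amine nitrogen in a ring. For the measured compounds named here, one measured step bears on this change: an at least 2.4-fold lower number from compound 1 to compound 2 (0.38 log units; beyond the scatter), which put pyrimidin-2-yl in place of ethyl at that same place. Butyl, like ethyl, has no ring, so compound 3 is expected to move back towards compound 1, giving a higher number in this assay, with a step of similar size or smaller. The expected change is a 2.0-fold higher number from compound 2 to compound 3 (0.29 log units; within the scatter). For compound 3 the estimated value is 4000000 nM, with an expected range from 1800000 nM to 9000000 nM.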

Compound 3, half-maximal inhibitory concentration: 1910000 nM
Beside the measured number, compound 3's estimate is 2.1-fold (0.32 log units) above it, within the range that was stated.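

In this assay, the change from pyrimidin-2-yl to butyl gives a 1.1-fold lower number from compound 2 to compound 3 (0.03 log units; within the scatter), so among the compounds shown, an aromatic ring at this nitrogen is not needed to reach a value like that of compound 2. The difference between the two chains matters more here, with an at least 2.6-fold lower number from compound 1 to compound 3 (0.41 log units; beyond the scatter), which means that ethyl and butyl do not behave alike at this position. The entry for compound 1 is a limit and not a number, so that step gives only the smallest size the change could have: the limit of > 5000000 nM in this assay, at which 1 of the 3 values shown sits.

The compounds shown leave open whether a longer chain such as hexyl would keep a value like that of compound 3. They also leave open how a phenyl ring, which has carbon atoms only, or a chain ending in a hydroxyl group would compare at this nitrogen.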